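The source may report more compounds than this note shows. Statements on the series, on what has been measured and on what is new or still open speak of the compounds shown alone.

Compound 1 `CCCSc1nc(N/N=C/c2ccccc2Cl)c2nnn(Cc3ccccc3)c2n1` belongs to a small set of compounds sharing one core. In a functional assay on MGC-803 cells (Homo sapiens) for antiproliferative activity, read by MTT assay, with a stated time of 72 h (on this read-out lower numbers stand for stronger inhibition and higher numbers for weaker inhibition), compound 1 gives 10900 nM; its number sits at the top of the three shown, yet within the usual scatter of both others, so no ordering among them is claimed. Compound 2 `CCCSc1nc(N/N=C/c2cc(OC)c(OC)c(OC)c2)c2nnn(Cc3ccccc3)c2n1` gives 9410 nM in this assay, and compound 3 `CCCSc1nc(N/N=C(\C)c2ccccc2O)c2nnn(Cc3cccc(Cl)c3)c2n1` gives 6500 nM in this assay. Compound 4 `CCCSc1nc(N/N=C/c2ccc3ccccc3c2)c2nnn(Cc3ccccc3)c2n1` has not been measured; it differs from compound 1 by naphthalen-2-yl in place of 2-chlorophenyl on a carbon with a double bond to nitrogen. Among the compounds with values here, no measured pair shows what this swap does, so the step of a 1.2-fold lower number from compound 1 to compound 4 (0.08 log units; within the scatter) in this assay is expected to be small, in no settled direction, and not beyond the scatter. Compound 4 is thus estimated to give about 9000 nM in this assay, within a range from 3000 nM to 30000 nM.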

Compound 4, half-maximal inhibitory concentration: > 64000 nM
Compound 4: only a limit was reported; the forecaster's own chance of this, stated with the estimate: 5%; at least 7.1-fold (0.85 log units) between middle value and limit.
By their numbers in this assay, from the lowest: compounds 3, 2 and 1 (each within the scatter of the next). At a limit, above all of these: compound 4.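

On a carbon with a double bond to nitrogen, naphthalen-2-yl in place of 2-chlorophenyl gives an at least 5.8-fold higher number from compound 1 to compound 4 (0.76 log units; beyond the scatter) in this assay. Within the data shown here, this shows that activity depends on the group at this position, which the earlier compounds, with no pair differing in one place, could not show. The size of the step is bounded rather than fixed, as compound 4 stands at a limit: the limit of > 64000 nM in this assay, at which 1 of the 4 values shown sits.

The compounds shown do not separate the effect of the added ring from that of the lost chlorine. They also leave open how an amine or a carboxylic acid would fare at this position.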